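Hydroxy for methoxy on a limit compound

A few compounds are considered here, and "the series" means these few. Any claim that something is new, unique, unknown or untested is made for them only; others in the source may bear on it.

- compound 1 `COc1cc(/C=C/C(O)=C/C(=O)/C=C/C2=C(C)CCCC2(C)C)ccc1O` gives 15800 nM in a functional assay on PC-3 cells (Homo sapiens) for cytotoxicity, read by MTT assay, with a stated time of 72 h; on this read-out lower numbers stand for stronger inhibition and higher numbers for weaker inhibition
- compound 2 `COc1cc(/C=C/C(O)=C/C(=O)/C=C/C2=C(C)CCCC2(C)C)cc(OC)c1OC` gives > 50000 nM as a limit in this assay

Compound 2 stands at a limit of this assay and has no number. Compound 3 `COc1cc(/C=C/C(O)=C/C(=O)/C=C/C2=C(C)CCCC2(C)C)cc(OC)c1O` differs from compound 2 in one place: hydrogen in place of methyl on an oxygen on an aromatic ring, methoxy to hydroxy. For the measured compounds named here, no measured pair shows this change, so the expectation is uncertain. Going by the values given here, it leans on compound 1 (15800 nM) as the only number available. A moderate shift toward stronger inhibition in this assay is expected, enough to bring the value within the measurable range. The estimated at least 3.5-fold lower number from compound 2 to compound 3 (0.55 log units; beyond the scatter) is read against a limit, so its size is only approximate. For compound 3 the expected value is 14000 nM (estimated range 5000 nM to 40000 nM).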

Compound 3, half-maximal inhibitory concentration: 26700 nM
Estimate against measurement, compound 3: 1.9-fold (0.28 log units) below, within the range that was stated.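

In this assay, for the compounds shown here, compound 3 gives a number where compound 2 does not, so methoxy to hydroxy on the aromatic ring now has a first reading: an at least 1.8-fold lower number from compound 2 to compound 3 (0.27 log units; that floor lies within the scatter). Compound 2 stands at a limit, so only a floor can be read for this step, and that floor does not clear the scatter: the limit of > 50000 nM in this assay, at which 1 of the 3 values shown sits. The other step shows that methoxy on the aromatic carbon does not separate the two phenols: a 1.7-fold higher number from compound 1 to compound 3 (0.23 log units; within the scatter).

From the compounds shown here alone, the true size of the step from compound 2 stays open, as does whether the single hydroxy or the full pattern of methoxy groups sets the value. Going by these compounds, how an amine or a longer alkoxy chain would read at this oxygen-bearing aromatic carbon also remains open.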